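Swapping methoxy for chloro on the terminal aryl ether

The source may report more compounds than this note shows. Statements on the series, on what has been measured and on what is new or still open speak of the compounds shown alone.

The three measured compounds share one core and differ in the tail that hangs from the oxygen on the aromatic ring. Compound 1, `CCOc1cc(=O)n(CCCO)c2c1CC(CC=C(C)C)C(C)(C)C2`, carries only a hydroxypropyl-type chain there; in a functional assay on PANC-1 cells (Homo sapiens) for inhibition, read by MTT assay, with a stated time of 24 h, tested at 10 uM (a lower number here means less inhibition, a higher number more inhibition at the concentration tested (going by the name of the read-out)), compound 1 gives 16.6%. Compound 2, `CC(C)=CCC1Cc2c(OCCCNS(=O)(=O)c3ccc(Cl)cc3)cc(=O)n(CCCO)c2CC1(C)C`, gives 9.8%, and compound 3, `COc1ccc(OCCCOc2cc(=O)n(CCCO)c3c2CC(CC=C(C)C)C(C)(C)C3)cc1`, gives 4.1%. Compound 3 thus stands lowest of the three numbers: the step of a number 12.5 percentage points lower from compound 1 to compound 3 (beyond the scatter), while the step of a number 5.7 percentage points lower from compound 2 to compound 3 (within the scatter) and the step of a number 6.8 percentage points lower from compound 1 to compound 2 (within the scatter).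

Compound 4, `CC(C)=CCC1Cc2c(OCCCOc3ccc(Cl)cc3)cc(=O)n(CCCO)c2CC1(C)C`, is compound 3 with chloro in place of methoxy on an aromatic carbon. For the measured compounds named here, no measured pair isolates this swap. The closest hint is that compound 2, which also bears a 4-chlorophenyl group though attached through a sulfonylamino linkage, and compound 3 sit within the scatter of each other, so a chloro on the terminal ring has not by itself moved the read-out. The expectation is therefore no step beyond the scatter: compound 4 is estimated at 7%, with a range from 0% to 18%, meaning an expected step of a number 2.9 percentage points higher from compound 3 to compound 4 (within the scatter).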

Compound 4, a percentage reported as inhibition, at one concentration (the size of the read-out at that concentration, not a potency): 0%
Beside the measured number, compound 4's estimate is 7 percentage points above it; measured number inside the range.
By their numbers in this assay, from the lowest: compounds 4, 3, 2 and 1 (each within the scatter of the next, the first and the last beyond it).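

In this assay the swap of chloro for methoxy, on an aromatic carbon para to a large group, can now be read on its own, and it gives a number 4.1 percentage points lower from compound 3 to compound 4 (within the scatter), so this change leaves the two aryl ethers inseparable at this position. With a 4-chlorophenyl group kept in the tail, 4-chlorophenoxy in place of ((4-chlorophenyl)sulfonyl)amino gives a number 9.8 percentage points lower from compound 2 to compound 4 (within the scatter), so that exchange cannot be told from scatter either, whereas adding the whole (4-chlorophenoxy)methyl in place of hydrogen gives a number 16.6 percentage points lower from compound 1 to compound 4 (beyond the scatter), a second aryl ether beyond the scatter of compound 1 alongside a number 12.5 percentage points lower from compound 1 to compound 3 (beyond the scatter). Nothing available explains how these tails act on the read-out.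

The compounds shown leave open whether a different group at this ring position, such as an amine, a carboxylic acid or a nitrile, would separate from methoxy and chloro in this assay. They also leave open how a longer chain between the core oxygen and the terminal ring, or a terminal phenyl ring carrying no substituent, would compare with compound 3 and compound 4.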